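A few compounds are considered here, and "the series" means these few. Any claim that something is new, unique, unknown or untested is made for them only; others in the source may bear on it.

Of the compounds shown here, two of a shared core have been measured in an ADME assay on the whole organism (strain Sprague-Dawley) for pharmacokinetics, with Rattus norvegicus as the target, read by LC-MS, at a dose of 25 mg/kg by the oral route; a lower number here means that a smaller share of the oral dose reaches the circulation, a higher number that a larger share of the oral dose reaches the circulation. Compound 1 `C=CC(=O)Nc1cccc(-n2c(=O)cc(C)c3cnc(Nc4ccccc4Nc4nc5c(s4)CN(C)CC5)nc32)c1` gives 0.6%. Compound 2 `C=CC(=O)Nc1cc(-n2c(=O)cc(C)c3cnc(Nc4ccc(N5CCN(C)C(C)C5)cc4OC)nc32)cc(C(F)(F)F)c1` gives 5.58%, a number that lies within the usual scatter of that of compound 1, so neither stands apart on what has been measured. Compound 3 `C=CC(=O)Nc1cccc(-n2c(=O)cc(C)c3cnc(Nc4ccc(N5CCN(C)C(C)C5)cc4OC)nc32)c1` is the untested partner of compound 2: hydrogen in place of trifluoromethyl on an aromatic carbon. For the measured compounds named here, no measured pair shows this kind of change, so the expectation for this assay rests only on the two low numbers seen so far, and a step of a number 1.6 percentage points lower from compound 2 to compound 3 (within the scatter) is expected, well within the scatter. Compound 3 is thus estimated at 4%, with a range of 0.5% to 15%.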

Compound 3, oral bioavailability: 24.3%
Estimate against measurement, compound 3: 20.3 percentage points below; the measured number lies above the stated range.
By their numbers in this assay, from the lowest: compounds 1 and 2 (each within the scatter of the next); then compound 3.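

In this assay, hydrogen in place of trifluoromethyl on this aromatic carbon gives a number 18.7 percentage points higher from compound 2 to compound 3 (beyond the scatter). For the compounds shown here, this is the first step between compounds differing in one place, and it shows that this position, meta to the (vinylcarbonyl)amino group, matters for the read-out. Nothing available explains the rise.

As far as these compounds go, whether chlorine, a nitrile or an amine on this carbon would land nearer compound 2 or compound 3 stays open. So does whether the same change would act alike on the core of compound 1.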